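The source may report more compounds than this note shows. Statements on the series, on what has been measured and on what is new or still open speak of the compounds shown alone.

Measured compounds:
Compound 1, `CCc1cccc(NC(=O)C2CCCN(C(=O)c3cc(C(F)(F)F)cc(C(F)(F)F)c3)C2)c1`, gives 0%.
Compound 2, `CSc1cccc(C(=O)N2CCCC(C(=O)Nc3ccc(Cl)cc3)C2)c1`, gives 0%.

Both measurements come from an ADME assay on PC-3 cells (Homo sapiens) for cytotoxicity, read by WST assay, tested at 100 uM; on this read-out lower numbers stand for less inhibition and higher numbers for more inhibition at the one concentration tested (going by the name of the read-out). Compound 1 stands level with compound 2 at the digits shown, and its nearest neighbour in this set is compound 2, with no change between them beyond the usual scatter of this assay. Neither compound shows any inhibition of the cells at the single concentration tested.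

The compound not yet measured is compound 3, `Cc1nc(-c2cccc(NC(=O)C3CCCN(C(=O)c4cc(C(F)(F)F)cc(C(F)(F)F)c4)C3)c2)cs1`. It differs from compound 1 in one place: 2-methyl-1,3-thiazol-4-yl in place of ethyl on an aromatic carbon. The group that enters is a five-membered aromatic ring with two hetero atoms, while the ethyl group that leaves is a short chain with no ring, so compound 3 is a somewhat larger molecule than compound 1.

Among the compounds with values here, no step between two measured compounds carries this kind of change, so there is no measured precedent to lean on. With compound 1 at 0%, the expected step is a number 5 percentage points higher from compound 1 to compound 3 (within the scatter), which is small and not expected to rise clearly out of the scatter. The estimate for compound 3 in this assay is 5%, with a range from 0% to 25%.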

Compound 3, a percentage reported as inhibition, at one concentration (the size of the read-out at that concentration, not a potency): 1%
Compound 3: middle estimate off by 4 percentage points, on the high side; measured number inside the range.
By their numbers in this assay, from the lowest: compounds 1, 2 and 3 (each within the scatter of the next).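

In this assay, putting 2-methyl-1,3-thiazol-4-yl in place of ethyl on this aromatic carbon gives a number 1 percentage points higher from compound 1 to compound 3 (within the scatter). This is the only step shown at this place, and it adds a clear change in structure: a short chain with no ring gives way to a five-membered aromatic ring with two hetero atoms and more heavy atoms, yet the cell read-out does not move beyond the scatter. So, for this one pair and at the single concentration tested, a larger ring group at this place on the 3-substituted phenyl brings no measurable gain in inhibition of the cells, and nothing among the data offers an explanation for that.

The compounds shown leave open whether any group at this place could lift the read-out clearly out of the scatter, for example an amine, a carboxylic acid or a longer chain. Within the data shown here, with only one step at this place, they also leave open whether the same result would hold if the two trifluoromethyl groups elsewhere in compound 3 were replaced.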